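The compounds below may be only part of what the source reports. "The series", "measured", "known", "first", "only" and "open" are said of these compounds alone.

Compound 1 `CC/C(=C\c1ccc(Cl)cc1)C(=O)/C=C/c1ccccc1Br`: 24400 nM
Compound 2 `CC/C(=C\c1ccc(Cl)cc1)C(=O)/C=C/c1ccc(C=O)cc1`: 46900 nM
Compound 3 `COc1ccc(/C=C(\C)C(=O)/C=C/c2c(Cl)cccc2Cl)cc1`: 65700 nM

All three compounds were tested in an ADME assay on Vero cells (Chlorocebus sabaeus) for cytotoxicity, read by MTT assay, with a stated time of 72 h; on this read-out higher numbers stand for lower toxicity in this test and lower numbers for higher toxicity in this test. Compound 2, at 46900 nM, sits in the middle of the three numbers, within the scatter of both compound 3 and compound 1.

Compound 4 `CC/C(=C\c1ccc(Cl)cc1)C(=O)/C=C/c1ccc(Cl)cc1` has not yet been measured in this assay. It keeps the core of compound 2 but carries chloro in place of formyl on an aromatic carbon, para to a large group: chloro in place of formyl on an aromatic carbon. Among the compounds with values here, no measured pair isolates this change, so its size cannot be read directly from the data. Like compound 4, compound 1 has no formyl and gives 24400 nM, which weakly suggests a lower number. Compound 3, also without formyl, goes against this with 65700 nM. The expected 1.6-fold lower number from compound 2 to compound 4 (0.19 log units; within the scatter) therefore stays within the scatter, leaning only slightly downward. For compound 4 the estimated value is 30000 nM, with an expected range from 13000 nM to 65000 nM.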

Compound 4, half-maximal cytotoxic concentration: 28300 nM
Compound 4: middle estimate off by 1.1-fold (0.03 log units), on the high side; low and high end bracket the measured number.
By their numbers in this assay, from the lowest: compounds 1, 4, 2 and 3 (each within the scatter of the next, the first and the last beyond it).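

In this assay, within the data shown here, the pair gives the first direct reading of chloro in place of formyl on this aromatic carbon, para to a large group: a 1.7-fold lower number from compound 2 to compound 4 (0.22 log units; within the scatter) is a step that stays within the scatter. Moving the comparison to the other aromatic end, 4-chlorophenyl in place of 2-bromophenyl gives a 1.2-fold higher number from compound 1 to compound 4 (0.06 log units; within the scatter) and likewise stays within the scatter, so neither change separates its two compounds on this shared core. Nothing measured here offers an explanation for either step.

From the compounds shown here alone, whether an amine or a carboxylic acid on this aromatic carbon would give a number beyond the scatter remains open. Going by these compounds, it also remains open whether chloro in place of formyl would give a step of similar size on a different core.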